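Shared-core amides: phenyl to pyridin-4-yl on the carbonyl

The source may hold more compounds than are shown below. What is called first, only, known or untested is meant among the compounds shown, and "the series" means these compounds.

compound 1, `O=C(Nc1cc(-c2ccccc2)nn1-c1ccccc1)c1ccccc1`: 203 nM
compound 2, `O=C(Nc1cc(-c2ccccc2)nn1-c1ccccc1Cl)c1ccccc1`: 62 nM
compound 3, `COc1cccc(-n2nc(-c3ccccc3)cc2NC(=O)c2ccccc2)c1`: 570 nM

In a functional assay on cells for positive allosteric modulation of metabotropic glutamate receptor 5 (Rattus norvegicus), read by calcium flux (on this read-out higher numbers stand for an effect only at larger amounts of compound and lower numbers for an effect already at smaller amounts), compound 1 gives 203 nM, the second highest of the three numbers. The nearest is compound 3, at a 2.8-fold higher number from compound 1 to compound 3 (0.45 log units; beyond the scatter); the furthest is compound 2, at a 3.3-fold lower number from compound 1 to compound 2 (0.52 log units; beyond the scatter). Compound 4, `O=C(Nc1cc(-c2ccccc2)nn1-c1ccccc1)c1ccncc1`, differs from compound 1 by pyridin-4-yl in place of phenyl on a carbonyl carbon. Among the compounds with values here, every measured step alters the group on the aromatic nitrogen; none touches the carbonyl side, so no measured step bears directly on this change. With nothing to lean on, a step within the scatter is expected for compound 4, a 1.5-fold higher number from compound 1 to compound 4 (0.17 log units; within the scatter), with wide uncertainty. The estimate for compound 4 in this assay is 300 nM, between 90 nM and 1000 nM.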

Compound 4, half-maximal effective concentration: 2500 nM
Compound 4: middle estimate off by 8.3-fold (0.92 log units), on the low side, and the stated range ends below it.
By their numbers in this assay, from the lowest: compound 2; then compound 1; then compound 3; then compound 4.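

Within the data shown here, the carbonyl side of the shared core, untouched by the earlier compounds, responds strongly in this assay: pyridin-4-yl in place of phenyl on the carbonyl carbon gives a 12-fold higher number from compound 1 to compound 4 (1.09 log units; beyond the scatter), the only step graded large so far. The change keeps the heavy-atom count and a six-membered aromatic ring, exchanging one ring carbon for nitrogen and adding one hydrogen-bond acceptor. Nothing available explains the size of this step.

Still open, as far as these compounds go, is whether a step of this size persists with 2-chlorophenyl on the aromatic nitrogen. Also open, from the compounds shown here alone, is how pyridin-3-yl, pyridin-2-yl or a saturated piperidine would read on the carbonyl carbon.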